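This account rests on a few compounds, and the source may have more. Where it says the series, first, only, none or still open, it means among the compounds named here.

Working notes on the series.

Three compounds of the shared core carry numbers in an assay on HEK293 cells for agonist activity at Bile acid receptor (Homo sapiens); on this read-out higher numbers stand for larger maximal responses and lower numbers for smaller maximal responses. Compound 1 `O=C(O)c1cncc(C2CC2c2ccc(OCc3c(-c4c(Cl)cccc4Cl)noc3C3CC3)cc2Cl)c1` gives 73% in this assay. Compound 2 `O=C(O)CNC(=O)c1ccc(C2CC2c2ccc(OCc3c(-c4c(Cl)cccc4Cl)noc3C3CC3)cc2Cl)cc1` gives 58% in this assay, and compound 3 `O=C(O)c1cccc([C@H]2C[C@](O)(c3ccc(OCc4c(-c5c(Cl)cccc5Cl)noc4C4CC4)cc3Cl)C2)c1` gives 79% in this assay. Among these three numbers compound 1 stands nearest to compound 3, a difference within the scatter of repeated runs, while its furthest neighbour is compound 2, whose number lies lower and beyond the scatter. Going by the values given here, no pair of these measured compounds differs in a single place, so no step between them is on record.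

Compound 4 `O=C(O)c1cccc([C@H]2C[C@@H]2c2ccc(OCc3c(-c4c(Cl)cccc4Cl)noc3C3CC3)cc2Cl)c1` is not yet measured in this assay. It differs from compound 1 as follows: 2-(3-carboxyphenyl)cyclopropyl in place of 2-(5-carboxypyridin-3-yl)cyclopropyl on an aromatic carbon. Among the compounds with values here, the only measured compound carrying the 2-(3-carboxyphenyl) motif on a three-membered ring is compound 3, which also carries a hydroxyl on that ring and gives 79% in this assay, a value within the scatter of compound 1.

On this basis compound 4 is expected to give a response close to compound 1, with a step of a number 3 percentage points higher from compound 1 to compound 4 (within the scatter) that would stay within the scatter in either direction. The estimate for compound 4 in this assay is 76%, with a range from 62% to 90%.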

Compound 4, largest response reached (reported as efficacy), in percent of the reference or control that the assay uses: 88%
Compound 4: middle estimate off by 12 percentage points, on the low side, and the stated range covers the measured number.
By their numbers in this assay, from the lowest: compound 2; then compounds 1, 3 and 4 (each within the scatter of the next, the first and the last beyond it).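

In this assay, going by these compounds alone, the change from 2-(5-carboxypyridin-3-yl)cyclopropyl to 2-(3-carboxyphenyl)cyclopropyl on the aromatic carbon ortho to a chloro group comes with a number 15 percentage points higher from compound 1 to compound 4 (beyond the scatter), the first single-place step, and it shows that the maximal response at this position is sensitive to a change that keeps the cyclopropyl and the carboxylic acid. The step combines two differences: a ring nitrogen gives way to carbon, with one hydrogen-bond acceptor fewer, and the entering group has 2 defined stereocentres, while none are printed for the leaving group, so the step cannot be assigned to either difference alone. Nothing on record explains the step.

Still open, going by these compounds, is how the response would move if the 2-(5-carboxypyridin-3-yl)cyclopropyl group carried the same defined stereocentres as the group in compound 4, or if the 2-(3-carboxyphenyl)cyclopropyl group carried the opposite configuration. The compounds shown also do not tell what a tetrazole or a primary amine in place of the carboxylic acid would do to the response.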